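From Bromo to Methoxy: An Expected Step in Growth Inhibition

The source may report more compounds than this note shows. Statements on the series, on what has been measured and on what is new or still open speak of the compounds shown alone.

The account covers three compounds measured in a functional assay on HL-60 cells (Homo sapiens) for antiproliferative activity, read by sulforhodamine B assay, with a stated time of 72 h (on this read-out higher numbers stand for weaker inhibition and lower numbers for stronger inhibition), and one still awaiting measurement. Compound 1, `S=C(N/N=C/c1ccc2ccccc2n1)Nc1ccc(Br)cc1`, gives 27500 nM in this assay. Compound 2, `CC(C)c1cccc(C(C)C)c1NC(=S)N/N=C/c1ccc2ccccc2n1`, gives 19500 nM in this assay, and the values of compound 1 and compound 2 lie within the scatter of each other, so neither can be set above the other. Compound 3, `NC(=S)N/N=C/c1cnc2ccccc2n1`, returns only a limit of the assay, > 100000 nM, in this assay. That entry is the limit of > 100000 nM in this assay, at which 1 of the 3 values shown sits, and it carries no number.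

Compound 4, `COc1ccc(NC(=S)N/N=C/c2ccc3ccccc3n2)cc1`, has not yet been measured in this assay. It differs from compound 1 in a single place: methoxy in place of bromo on an aromatic carbon. No measured pair shows this exchange, so its size is not fixed by the data shown. With compound 1 and compound 2 sitting close together despite their different aryl groups, and no shown evidence that this exchange moves the number either way, the step is expected to be small. The step of a 1.1-fold lower number from compound 1 to compound 4 (0.04 log units; within the scatter) is expected to stay within the scatter in either direction. Compound 4 is therefore expected to give about 25000 nM in this assay, with a range from 8000 nM to 80000 nM.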

Compound 4, half-maximal inhibitory concentration: 43800 nM
Estimate against measurement, compound 4: 1.8-fold (0.24 log units) below; measured number inside the range.
By their numbers in this assay, from the lowest: compounds 2, 1 and 4 (each within the scatter of the next, the first and the last beyond it). At a limit, above all of these: compound 3.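

In this assay, the exchange of 4-bromophenyl for 4-methoxyphenyl, on an aromatic carbon para to a large group, gives a 1.6-fold higher number from compound 1 to compound 4 (0.20 log units; within the scatter), so the read-out does not separate the two compounds. Among these compounds, this is the first single-place step in the set that can be read at all, and it shows that at this position a bromine atom can give way to a methoxy group, with its extra heavy atom, its oxygen and the hydrogen-bond acceptor counted for it, without a change that stands clear of the scatter. Nothing in the data shown gives a reason for this step, and one exchange at one position cannot supply it.

On these data alone, whether an amine, a carboxylic acid, a plain hydrogen or a longer chain such as ethoxy at this same position would give a step beyond the scatter remains open. Among the compounds shown here, also open is whether the methoxy for bromo exchange would give a step of similar size at another aromatic carbon of the ring, or on a core other than the one shared by compound 1 and compound 4.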